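The source may hold more compounds than are shown below. What is called first, only, known or untested is meant among the compounds shown, and "the series" means these compounds.

Compound 1 `COc1ccc(-c2c(C)nn3c(NCc4ccc(N(C)C)cc4)cc(C)nc23)cc1OC` and compound 2 `COc1ccc(-c2c(C)nn3c(NCc4cccnc4)cc(C)nc23)cc1OC` share one core; compound 3 `COc1ccc(-c2c(C)nn3c(NCc4ccc(N(C)C)cc4)nc(C)nc23)cc1OC` and compound 4 `COc1ccc(-c2c(C)nn3c(NCc4cccnc4)nc(C)nc23)cc1OC` share another. The difference between the two cores is not broken down here. In a physicochemical assay for acid dissociation, compound 1 gives 5.4, and compound 2 gives 5.4. The change from compound 1 to compound 2 is pyridin-3-yl in place of 4-(dimethylamino)phenyl on a saturated chain carbon bound to a nitrogen on an aromatic ring, and its step was no change at the digits printed from compound 1 to compound 2 (within the scatter). In this assay compound 3 gives 2.9, the lowest of the three numbers. Compound 4 carries the same change against compound 3, namely (pyridin-3-yl in place of 4-(dimethylamino)phenyl on a saturated chain carbon bound to a nitrogen on an aromatic ring), made on the core of compound 3. From the compounds shown here alone, because the earlier step of no change at the digits printed from compound 1 to compound 2 (within the scatter) stayed within the scatter, the step from compound 3 to compound 4 is expected to be similar, about no change at the digits printed from compound 3 to compound 4 (within the scatter), though the core of compound 3 is untested with this change. Compound 4 is therefore estimated at 2.9, between 2.3 and 4.5.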

Compound 4, acid dissociation constant: 2.5
Compound 4: the middle estimate sits 0.40 log units above what was measured, and the stated range covers the measured number.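

In this assay the change to pyridin-3-yl gave no change at the digits printed from compound 1 to compound 2 (within the scatter) on the first core, but a number 0.40 log units lower from compound 3 to compound 4 (beyond the scatter) on the second. This shows that a step within the scatter on one core did not stay within it on the other, although the shift remained modest; with one pair on each core, it does not show a general rule for either core or for other changes in this series. Nothing shown here accounts for the different outcome on the two cores.

From the compounds shown here alone, it remains open how a morpholine, a piperidine or a carboxylic acid on the same saturated chain carbon would behave on each core. Going by these compounds, a longer chain leading to the pyridin-3-yl group is equally open.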